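The compounds below may be only part of what the source reports. "The series", "measured", "known", "first", "only" and "open" are said of these compounds alone.

Measured so far in a functional assay on SMMC-7721 cells (Homo sapiens) for cytotoxicity, read by MTT assay, with a stated time of 4 days; on this read-out lower numbers stand for stronger inhibition and higher numbers for weaker inhibition:

Compound 1 `Cc1ccc(S(=O)(=O)Oc2ccc3c(c2C)[C@H](Cn2cc(-c4ccccn4)nn2)[C@@]24CC(=O)[C@@](C)(CC[C@@H]32)C4)cc1` — in this assay compound 1 reaches only the assay limit, > 20000 nM.

Compound 2 `COc1ccc(-c2cn(C[C@H]3c4c(ccc(OS(=O)(=O)c5ccc(C)cc5)c4C)[C@@H]4CC[C@@]5(C)C[C@]43CC5=O)nn2)cc1` — in this assay compound 2 likewise reaches only the assay limit, > 20000 nM.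

Compound 3 `Cc1c(O)ccc2c1[C@H](Cn1cc(-c3ccc(C(F)(F)F)cc3)nn1)[C@@]13CC(=O)[C@@](C)(CC[C@@H]21)C3` — in this assay compound 3 also stops at the assay limit, > 20000 nM.

Compound 3 therefore stands nowhere above the rest of the set: every value shown is a limit, not a number, which is the limit of > 20000 nM in this assay, at which 3 of the 3 values shown sit. No ordering among the three can be read from this.

The step to be followed goes from compound 3 to compound 4 `Cc1ccc(S(=O)(=O)Oc2ccc3c(c2C)[C@H](Cn2cc(-c4ccc(C(F)(F)F)cc4)nn2)[C@@]24CC(=O)[C@@](C)(CC[C@@H]32)C4)cc1`. The change is (4-methylphenyl)sulfonyl in place of hydrogen on an oxygen on an aromatic ring. Compound 4 thus carries the same ((4-methylphenyl)sulfonyl)oxy group as compound 1 and compound 2, joined to the aryl-triazole of compound 3.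

Going by the values given here, only one measured step connects two compounds that differ in a single place, and it does not read: a step that the two limits leave unreadable from compound 1 to compound 2. It concerns the aryl on the triazole, not the oxygen substituent, so it does not speak to the change in hand. Among the compounds with values here, compound 1 and compound 2, which already bear the entering group, both give limits and not numbers, and compound 3 gives a limit without it; no measured step distinguishes hydroxy from the sulfonate ester here.

Accordingly no movement beyond the scatter is expected, and the step is estimated as a step that the limit leaves unreadable from compound 3 to compound 4. Compound 4 is expected to give about 30000 nM in this assay, within 10000 nM to 100000 nM, most likely again as a limit rather than a number.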

Compound 4, half-maximal inhibitory concentration: > 20000 nM
Compound 4 ended at the assay's limit; the forecaster's own chance of this, stated with the estimate: 85%; the middle value is on the limit's open side.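

No new step can be read among compound 1, compound 2, compound 3 and compound 4, because each value is a limit and not a number: the limit of > 20000 nM in this assay, at which 4 of the 4 values shown sit. The compounds shown leave open whether changing the aryl on the triazole, or hydroxy to ((4-methylphenyl)sulfonyl)oxy, shifts the read-out at all in this assay.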